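Cyclobutyl to 1-(Trifluoromethyl)cyclopropyl on a Stable Core

A few compounds are considered here, and "the series" means these few. Any claim that something is new, unique, unknown or untested is made for them only; others in the source may bear on it.

Compound 1, `CC(C)CCn1nc(-c2cccs2)c(O)c(C2=NS(=O)(=O)c3cc(NS(=O)(=O)C4CC4)ccc3N2)c1=O`, reaches the limit of > 1 h in an in vitro ADME assay on microsomes from liver (Homo sapiens) for metabolic stability, tested at 5 uM (a higher number here means that the compound lasts longer, a lower number that the compound disappears faster), a limit rather than a number.
Compound 2, `CS(=O)(=O)Nc1ccc2c(c1)S(=O)(=O)N=C(c1c(O)c(-c3cccs3)nn(CC3CCC3)c1=O)N2`, likewise reaches the limit of > 1 h in this assay.

Both measured compounds therefore sit at the same ceiling: the limit of > 1 h in this assay, at which 2 of the 2 values shown sit. Going by the values given here, compound 2 stands at that limit, so its true half-life is known only to be beyond the reach of the assay, and no step between two measured compounds exists that could show how a change at this position moves the read-out.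

Compound 3, `CS(=O)(=O)Nc1ccc2c(c1)S(=O)(=O)N=C(c1c(O)c(-c3cccs3)nn(CC3(C(F)(F)F)CC3)c1=O)N2`, is the unmeasured compound. It differs from compound 2 in one place: 1-(trifluoromethyl)cyclopropyl in place of cyclobutyl on a saturated chain carbon bound to an aromatic nitrogen. Among the compounds with values here, since compound 2 gives only a limit, the expectation for compound 3 rests on the fact that every value so far lies at that limit, and no step beyond the usual scatter is expected in either direction in this assay. Compound 3 is expected to give about 1.3 h, within a range of 0.7 h to 2.5 h, most likely reported again as a limit. This corresponds to an expected step that the limit leaves unreadable from compound 2 to compound 3.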

Compound 3, half-life: > 1 h
Compound 3 gave a limit, no number; the forecaster's own chance of this, stated with the estimate: 70%; the middle value does not contradict the limit.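

In this assay compound 3 gives > 1 h as a limit, not a number. Going by these compounds alone, compound 2 gives a limit too, so no step from compound 2 to compound 3 can be read. How long compound 2 and compound 3 really last, and whether cyclobutyl and 1-(trifluoromethyl)cyclopropyl differ here at all, stays open: the limit of > 1 h in this assay, at which 3 of the 3 values shown sit.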